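Bromo in Place of Methoxy Where Every Relative Sits at a Limit

This account rests on a few compounds, and the source may have more. Where it says the series, first, only, none or still open, it means among the compounds named here.

In a functional assay on SW480 cells (Homo sapiens) for cytotoxicity, read by MTT assay, with a stated time of 4 days (on this read-out lower numbers stand for stronger inhibition and higher numbers for weaker inhibition), compound 1 `Cc1ccc(S(=O)(=O)Oc2ccc3c(c2C)[C@H](Cn2cc(-c4ccccc4)nn2)[C@@]24CC(=O)[C@@](C)(CC[C@@H]32)C4)cc1` gives only a limit, > 20000 nM. Compound 2 `Cc1ccc(S(=O)(=O)Oc2ccc3c(c2C)[C@H](Cn2cc(-c4ccc(Cl)cc4)nn2)[C@@]24CC(=O)[C@@](C)(CC[C@@H]32)C4)cc1` likewise reaches only a limit in this assay, > 20000 nM. Compound 3 `COc1ccc(-c2cn(C[C@H]3c4c(ccc(OS(=O)(=O)c5ccc(C)cc5)c4C)[C@@H]4CC[C@@]5(C)C[C@]43CC5=O)nn2)cc1`, the starting point here, also gives only a limit in this assay, > 20000 nM. Because all three values sit at the limit of > 20000 nM in this assay, at which 3 of the 3 values shown sit, the steps among them cannot be read: a step that the two limits leave unreadable from compound 1 to compound 2, a step that the two limits leave unreadable from compound 1 to compound 3 and a step that the two limits leave unreadable from compound 2 to compound 3. Compound 3 therefore stands exactly where its two relatives stand, at a limit, with no number to separate it from either of them.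

Compound 4 `Cc1ccc(S(=O)(=O)Oc2ccc3c(c2C)[C@H](Cn2cc(-c4ccc(Br)cc4)nn2)[C@@]24CC(=O)[C@@](C)(CC[C@@H]32)C4)cc1` differs from compound 3 in one place: bromo in place of methoxy on an aromatic carbon. The measured steps that bear on this change are the three unreadable ones above, in which hydrogen, chloro and methoxy on an aromatic carbon of that ring all left the compound at a limit. None of them shows a group at that carbon bringing a measurable value. A bromo group there is expected to behave as the chloro and methoxy did, and the step from compound 3 to compound 4 is estimated as a step that the limit leaves unreadable from compound 3 to compound 4, that is, nothing beyond the scatter. Compound 4 is expected to give 30000 nM, within a range of 12000 nM to 80000 nM, most likely reported again only as a limit.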

Compound 4, half-maximal inhibitory concentration: > 20000 nM
Compound 4 gave a limit, no number (the forecaster's own chance of this, stated with the estimate: 80%); the middle value is on the limit's open side.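

In this assay compound 4 gives > 20000 nM, which is a limit and not a number. Its steps to compound 1, compound 2 and compound 3 cannot be read, because all four values sit at one limit: the limit of > 20000 nM in this assay, at which 4 of the 4 values shown sit. The compounds shown leave open how far apart these four truly lie, and whether any group at that aromatic carbon could bring a measurable value.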